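Ethoxy for Propyl: One Change, Little Movement Expected

A few compounds are considered here, and "the series" means these few. Any claim that something is new, unique, unknown or untested is made for them only; others in the source may bear on it.

Compound 1 `CCCc1ccc(NC2=CC(=O)c3nc4n(c3C2=O)[C@H]2OC[C@@H](O)[C@H]2OC4)cc1`: 4990 nM
Compound 2 `O=C1C(N2CCCC2)=CC(=O)c2c1nc1n2[C@H]2OC[C@@H](O)[C@H]2OC1`: > 16000 nM (a limit of the assay)

Among the measured compounds shown here, in a functional assay on HeLa cells (Homo sapiens) for inhibition, read by sulforhodamine B assay (on this read-out lower numbers stand for stronger inhibition and higher numbers for weaker inhibition), compound 1 gives 4990 nM, the only numerical value among the two measured compounds. Compound 2 reaches only a limit of this assay, > 16000 nM, so for it no number is known. That limit is described by the limit of > 16000 nM in this assay, at which 1 of the 2 values shown sits. For the measured compounds named here, no two measured compounds differ in a single place, so no measured step is available; the two values show merely that compound 1 gives a number where compound 2 does not.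

Compound 3 `CCOc1ccc(NC2=CC(=O)c3nc4n(c3C2=O)[C@H]2OC[C@@H](O)[C@H]2OC4)cc1` differs from compound 1 by ethoxy in place of propyl on an aromatic carbon. The group that leaves and the group that enters sit at the same place, on an aromatic carbon para to a large group, and the change is ethoxy in place of propyl.

With nothing measured on this kind of change, the step from compound 1 to compound 3 is expected to stay within the usual scatter, so a 1.0-fold higher number from compound 1 to compound 3 (0.00 log units; within the scatter) is the estimate, in no clear direction. Compound 3 is therefore expected to give about 5000 nM in this assay, with a range from 2000 nM to 13000 nM.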

Compound 3, half-maximal inhibitory concentration: 3110 nM
Beside the measured number, compound 3's estimate is 1.6-fold (0.21 log units) above it; the range from low to high includes it.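

In this assay, among the compounds shown here, the exchange of 4-propylphenyl for 4-ethoxyphenyl gives the only measured step at this position, a 1.6-fold lower number from compound 1 to compound 3 (0.21 log units; within the scatter) and so, on this aromatic carbon of the shared core, ethoxy in place of propyl makes no difference that can be told from the scatter. For the compounds shown here, this is what the earlier compounds could not show: compound 1 and compound 3 differ in one place only, and the oxygen that enters, with its hydrogen-bond acceptor, leaves the read-out within the scatter of the propyl compound. Nothing measured here gives a reason for this result or bears on any cause behind it.

What the compounds shown leave open is how far this tolerance reaches: whether a longer chain such as butoxy, an amine or a carboxylic acid on the same aromatic carbon would also stay within the scatter of compound 1 remains unknown. Also open, on these data alone, is whether ethoxy in place of propyl would behave the same way on a different core, or in any read-out other than this one.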